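The source may hold more compounds than are shown below. What is called first, only, known or untested is meant among the compounds shown, and "the series" means these compounds.

Measured compounds, with their results in an assay on isolated protein for inhibition of Nicotinamide phosphoribosyltransferase (Homo sapiens), read by mass spectrometry, with stated times of 15 min and 30 min; a lower number here means a stronger inhibitor, a higher number a weaker inhibitor:

compound 1 `O=C(NCc1ccc(S(=O)(=O)c2ccccc2)cc1)N1CCc2ccncc2C1`: 310 nM
compound 2 `O=S(=O)(c1ccccc1)c1ccc(CNS(=O)(=O)N2Cc3ccncc3C2)cc1`: > 2000 nM
compound 3 `CC(C)n1cc(S(=O)(=O)c2ccc(CNC(=O)N3Cc4ccncc4C3)cc2)cn1`: 20 nM

The value of compound 2 is a limit of this assay and not a number (the limit of > 2000 nM in this assay, at which 1 of the 3 values shown sits). Among the two numbers shown, compound 3 has the lower one, and the gap to compound 1 lies beyond the usual scatter.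

The untested compound 4 `CC(=O)N1CCC(S(=O)(=O)c2ccc(CNC(=O)N3Cc4ccncc4C3)cc2)CC1` differs from compound 3 in one place: 1-acetylpiperidin-4-yl in place of 1-isopropyl-1H-pyrazol-4-yl on a sulfonyl sulfur. No such swap of a sulfone substituent has been measured here, so the expected step from compound 3 to compound 4 in this assay, a 3.0-fold higher number from compound 3 to compound 4 (0.48 log units; beyond the scatter), is estimated as a modest weakening, possibly within the scatter. Compound 4 is expected to give about 60 nM, in a range from 15 nM to 300 nM.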

Compound 4, half-maximal inhibitory concentration: 83 nM
Beside the measured number, compound 4's estimate is 1.4-fold (0.14 log units) below it; measured number inside the range.
By their numbers in this assay, from the lowest: compound 3; then compound 4; then compound 1. At a limit, above all of these: compound 2.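

In this assay, among the compounds shown here, changing the group on the sulfonyl sulfur gives a 4.2-fold higher number from compound 3 to compound 4 (0.62 log units; beyond the scatter), the first measured step at this place. An aromatic ring on the sulfur is therefore not essential for activity: with the non-aromatic 1-acetylpiperidin-4-yl, compound 4 still gives 83 nM, although 1-isopropyl-1H-pyrazol-4-yl gives the lower number. Nothing measured here explains the size of this step. As far as these compounds go, it remains open whether the acetyl group itself contributes, and how a piperidine with a free amine or a tetrahydropyran ring would compare at this place.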